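This account rests on a few compounds, and the source may have more. Where it says the series, first, only, none or still open, it means among the compounds named here.

Measured in an assay on isolated protein with adenosine receptor A1 (Homo sapiens) as the target, read by ERK phosphorylation; on this read-out higher numbers stand for higher potency (the scale is a negative logarithm) and lower numbers for lower potency:
- compound 1 `Nc1sc2c(c1C(=O)c1ccccc1)CCCCCC2`: 5.08
- compound 2 `Nc1sc(-c2cncnc2)cc1C(=O)c1ccccc1`: 5.82

Compound 2 holds the higher of the two numbers; its nearest neighbour, compound 1, gives 5.08 in this assay, a gap that lies beyond the usual scatter. Within the data shown here, the two differ at more than one place, so the numbers say only that compound 2 is the more potent of the pair.

Compound 3 `Nc1sc(-c2ccccc2)cc1C(=O)c1ccccc1` is not yet measured. Compared with compound 2 the change is phenyl in place of pyrimidin-5-yl on an aromatic carbon. Among the measured compounds shown here, no measured pair carries this kind of swap, so no step size can be read off for it. In this assay the expected outcome for compound 3 is a step of a number 0.08 log units higher from compound 2 to compound 3 (within the scatter), that is, no move beyond the scatter in either direction. The estimate for compound 3 is 5.9, with a range from 5.2 to 6.6.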

Compound 3, negative logarithm of the antagonist equilibrium constant: 6.36
The estimate for compound 3 lay 0.46 log units below the measured number, and the stated range covers the measured number.
By their numbers in this assay, from the lowest: compound 1; then compound 2; then compound 3.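

Among these compounds, at the aromatic carbon next to the ring sulfur, the swap of pyrimidin-5-yl for phenyl gives the only single-place comparison: in this assay the change produces a number 0.54 log units higher from compound 2 to compound 3 (beyond the scatter) and sets the all-carbon ring above the ring with 2 hetero atoms at this position. The two groups match in heavy atoms and ring size, so the comparison isolates the exchange of ring nitrogen for ring carbon, with the 2 hydrogen-bond acceptors leaving along with it. Nothing available here accounts for the step.

Pyridin-3-yl, with a single ring nitrogen, would show whether the gain needs both nitrogens gone. A chlorine or a methoxy group on the phenyl would test whether this position takes more than the bare ring.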